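Replacing the Propyl Group of Compound 1

The source may hold more compounds than are shown below. What is called first, only, known or untested is meant among the compounds shown, and "the series" means these compounds.

Three amides sharing one core have been tested in a functional assay on MGC-803 cells (Homo sapiens) for inhibition, read by MTT assay, with a stated time of 72 h; a lower number here means a stronger inhibitor, a higher number a weaker inhibitor. Compound 1 `CCCc1ccc(NC(=O)C2CCN(C/C=C/c3ccccc3)CC2)cc1` gives 5210 nM, the lowest number of the three. Compound 3 `O=C(Nc1cccc(Cl)c1)C1CCN(C/C=C/c2ccccc2)CC1`, with 3-chlorophenyl on the amide nitrogen, gives 11300 nM. Compound 2 `COc1ccccc1NC(=O)C1CCN(C/C=C/c2ccccc2)CC1`, with 2-methoxyphenyl there, gives 71200 nM.

Compound 4 `CN1CCN(c2ccc(NC(=O)C3CCN(C/C=C/c4ccccc4)CC3)cc2)CC1` has not yet been measured. It keeps the core of compound 1 but has 4-methylpiperazin-1-yl in place of propyl on an aromatic carbon. Among the measured compounds shown here, no measured compound carries this group, so the evidence is only indirect. The closest guides are the two changes that replaced the whole 4-propylphenyl group. One is modest, a 2.2-fold higher number from compound 1 to compound 3 (0.34 log units; beyond the scatter), and the other is large, a 14-fold higher number from compound 1 to compound 2 (1.14 log units; beyond the scatter). The two replacements themselves differ clearly, a 6.3-fold lower number from compound 2 to compound 3 (0.80 log units; beyond the scatter), so the outcome depends strongly on the group chosen. Both changes raised the number, but two examples are a thin basis. A modest move towards a weaker inhibitor is expected, and the estimated step is a 2.3-fold higher number from compound 1 to compound 4 (0.36 log units; beyond the scatter). A large step remains possible, and a result close to the starting value cannot be ruled out. In this assay, compound 4 is estimated at 12000 nM, with an expected range from 3000 nM to 50000 nM.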

Compound 4, half-maximal inhibitory concentration: 14000 nM
The estimate for compound 4 lay 1.2-fold (0.07 log units) below the measured number; low and high end bracket the measured number.
By their numbers in this assay, from the lowest: compound 1; then compounds 3 and 4 (each within the scatter of the next); then compound 2.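

Among the compounds shown here, compound 4 is the only compound here that keeps the phenyl ring on the amide nitrogen and changes just the group on an aromatic carbon, para to a large group, so it isolates this position in a way compounds 2 and 3 could not. In this assay, exchanging propyl for 4-methylpiperazin-1-yl gives a 2.7-fold higher number from compound 1 to compound 4 (0.43 log units; beyond the scatter), a modest loss, even though the entering group has more heavy atoms, a six-membered non-aromatic ring and two hydrogen-bond acceptors that propyl lacks. No measurement available here explains why the number rises.

The two compounds at this position differ in several features at once, so they leave open whether the modest loss follows from the size of the group, its ring or its nitrogen atoms. A longer chain such as butyl, a morpholine ring with oxygen in place of the methyl-bearing nitrogen, or a small open amine such as dimethylamino at the same position would help to separate these features.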